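Shortening a propyl chain on the shared core

The compounds below may be only part of what the source reports. "The series", "measured", "known", "first", "only" and "open" are said of these compounds alone.

Measured compounds:
- compound 1, `CCCCCCCCCCn1cc(-c2nc3ccccc3cc2CCC)nn1`: > 100 ug/mL
- compound 2, `CCCc1cc2ccccc2nc1-c1cn(CCC(F)(F)C(F)(F)C(F)(F)C(F)(F)C(F)(F)C(F)(F)C(F)(F)C(F)(F)F)nn1`: 37.8 ug/mL

Of the compounds shown here, two have been measured in a functional assay on HeLa cells (Homo sapiens) for cytotoxicity, read by MTT assay, with a stated time of 24 h; on this read-out lower numbers stand for stronger inhibition and higher numbers for weaker inhibition. Compound 1 gave no number there; its result is a limit of the assay, (the limit of > 100 ug/mL in this assay, at which 1 of the 2 values shown sits), so where compound 1 truly stands is not known, only that it is at or beyond that limit. Compound 2, which carries a long fluorinated chain instead of the plain decyl chain, gives a number in this assay, 37.8 ug/mL. For the measured compounds named here, because the two compounds differ in more than one place, no single step between them is set out here, and only their two values can be read.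

The next compound is compound 3, `CCCCCCCCCCn1cc(-c2nc3ccccc3cc2CC)nn1`. It differs from compound 1 in one place only: hydrogen in place of methyl on a saturated chain carbon, two bonds along the chain from an aromatic carbon. Going by the values given here, no measured step of this kind is available for comparison. With compound 1 at a limit and so small a change, no shift beyond the usual scatter is expected; the step from compound 1 to compound 3 is estimated at a step that the limit leaves unreadable from compound 1 to compound 3. Compound 3 is therefore expected to give about 150 ug/mL, within a range of 60 ug/mL to 400 ug/mL, and most likely again only a limit.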

Compound 3, half-maximal inhibitory concentration: > 100 ug/mL
Compound 3: a limit, no number; the forecaster's own chance of this, stated with the estimate: 75%; the middle value does not contradict the limit.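

In this assay, for the compounds shown here, compound 3 gives only a limit, as compound 1 does, so no step from compound 1 to compound 3 can be read, because both results sit at the same limit: (the limit of > 100 ug/mL in this assay, at which 2 of the 3 values shown sit). The compounds shown leave open how far either one truly lies beyond that limit, and whether going from propyl to ethyl changes the read-out at all.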